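This account rests on a few compounds, and the source may have more. Where it says the series, first, only, none or still open, it means among the compounds named here.

Within the data shown here, in an ADME assay on Vero cells (Chlorocebus sabaeus) for cytotoxicity, read by sulforhodamine B assay, with a stated time of 72 h (on this read-out lower numbers stand for stronger inhibition and higher numbers for weaker inhibition), compound 3 `CN1Cc2ccc(OCc3ccc(Oc4ccccc4)cc3)cc2[C@@H](O)C1` gives 3400 nM, the only outright number among the three measured compounds. Compound 1 `Cc1ccccc1COc1ccc2c(c1)[C@@H](O)CN(C)C2` reaches only a limit, > 100000 nM, which is the limit of > 100000 nM in this assay, at which 1 of the 3 values shown sits. Compound 2 `CN1Cc2ccc(OCCCc3ccccc3)cc2[C@@H](O)C1` likewise reaches only a limit, > 50000 nM, which is the limit of > 50000 nM in this assay, at which 1 of the 3 values shown sits. Among the measured compounds shown here, compound 3 thus stands alone as the one compound with a concentration actually resolved in this assay. Compound 4 `CN1Cc2ccc(OCc3ccc(-c4ccc(Cl)cc4)cc3)cc2[C@@H](O)C1` differs from compound 3 by 4-chlorophenyl in place of phenoxy on an aromatic carbon. For the measured compounds named here, no measured pair in this set shares that change, so no measured step can guide the estimate directly. The step is expected to be a 1.1-fold lower number from compound 3 to compound 4 (0.05 log units; within the scatter), a size that stays within the usual scatter. Compound 4 is therefore estimated at 3000 nM, with a range from 1000 nM to 10000 nM.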

Compound 4, half-maximal inhibitory concentration: 21700 nM
Compound 4: the middle estimate sits 7.2-fold (0.86 log units) below what was measured; the whole stated range lies below it.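

Among these compounds, the change from phenoxy to 4-chlorophenyl, on an aromatic carbon para to a large group, gives the only measured step in this assay: a 6.4-fold higher number from compound 3 to compound 4 (0.80 log units; beyond the scatter). The two groups match in heavy-atom count and each holds one six-membered aromatic ring of carbon only, yet they are not interchangeable at this place. Nothing among the values shown accounts for the step. Going by these compounds, it remains open whether the chlorine or the loss of the oxygen carries the step, which a plain phenyl at this place would separate. On these data alone, how an amine or a carboxylic acid would read here is also open.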